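A few compounds are considered here, and "the series" means these few. Any claim that something is new, unique, unknown or untested is made for them only; others in the source may bear on it.

Measured compounds:
compound 1 `O=C(NS(=O)(=O)C1CCOCC1)c1ccc(N2C[C@@H]3C[C@H]2C[C@H]3OCc2c(C3CC3)cnn2-c2c(Cl)cccc2Cl)cc1` — 116%
compound 2 `O=C(O)c1cc(OC2CC2)c2nc(N3C[C@@H]4C[C@H]3C[C@H]4OCc3c(C4CC4)cnn3-c3c(Cl)cccc3Cl)sc2c1` — 116%

Both compounds share the same bridged amine core carrying the pyrazole and dichlorophenyl groups, and they differ only in the acidic part attached to it. In an assay on HEK293T cells for agonist activity at Bile acid receptor (Homo sapiens) (on this read-out higher numbers stand for larger maximal responses and lower numbers for smaller maximal responses), compound 1 gives 116%, and in this assay compound 2 gives 116%. Compound 2 thus stands level with compound 1 at the digits shown, the two values lying within the usual scatter of repeated measurements. For the measured compounds named here, no pair of measured compounds differs in just one place, so no measured step is available to lean on.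

Compound 3 `O=C(O)c1cc(C2CCOCC2)c2nc(N3C[C@@H]4C[C@H]3C[C@H]4OCc3c(C4CC4)cnn3-c3c(Cl)cccc3Cl)sc2c1` keeps the core of compound 2 and carries the change (oxan-4-yl in place of cyclopropyloxy on an aromatic carbon). Both measured compounds reach a full maximal response, and the swap of one neutral oxygen-containing group for another is expected to leave the maximal response roughly unchanged, so the step of a number 6 percentage points lower from compound 2 to compound 3 (within the scatter) is expected to be none beyond the scatter. Compound 3 is therefore estimated to give about 110% in this assay, with a range from 90% to 130%.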

Compound 3, largest response reached (Emax), in percent of the reference or control that the assay uses: 116%
Estimate against measurement, compound 3: 6 percentage points below; low and high end bracket the measured number.
By their numbers in this assay, from the lowest: compounds 1, 2 and 3 (each within the scatter of the next).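

In this assay, oxan-4-yl in place of cyclopropyloxy on the aromatic carbon meta to the carboxy group gives no change at the digits printed from compound 2 to compound 3 (within the scatter). For the compounds shown here, this is the first measured pair that differs in one place, and it shows that, for these two groups, the larger six-membered ring and the three-membered ring joined through oxygen give the same maximal response at this position. Nothing measured here accounts for that outcome.

The compounds shown leave open whether an amine, a longer alkyl chain or a plain hydrogen on this aromatic carbon would hold the maximal response as well. They also leave open whether the two groups would still match on a read-out of potency rather than of maximal response.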